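The compounds below may be only part of what the source reports. "The series", "measured", "known", "first", "only" and "open" are said of these compounds alone.

This account follows a small set tested in an ADME assay on GES1 cells (Homo sapiens) for inhibition, read by MTT assay, with a stated time of 72 h; on this read-out lower numbers stand for stronger inhibition and higher numbers for weaker inhibition. Compound 1, `Cc1cc(Nc2cc(-c3ccccc3)[nH]n2)n2nc(SCc3cccc(Br)c3)nc2n1`, returns in this assay only a limit, > 50000 nM; that result is the limit of > 50000 nM in this assay, at which 1 of the 2 values shown sits. Compound 2, `Cc1cc(Nc2cc(-c3ccc(Cl)cc3)[nH]n2)n2nc(SCc3ccc(Br)cc3)nc2n1`, gives in this assay 28200 nM, and this is the only numerical value among the results shown, so compound 2 stands alone as the sole measured number, with no measured step to another compound to set it against. The unmeasured compound 3, `Cc1cc(Nc2cc(-c3ccccc3)[nH]n2)n2nc(SCc3ccc(Br)cc3)nc2n1`, differs from compound 2 by hydrogen in place of chloro on an aromatic carbon, a change that, viewed one bond further out, reads as 4-chlorophenyl to phenyl. Going by the values given here, with no measured step in hand, the step from compound 2 to compound 3 is expected to be a 1.6-fold higher number from compound 2 to compound 3 (0.20 log units; within the scatter), in the direction of weaker inhibition, quite possibly ending at the limit. Compound 3 is accordingly estimated at 45000 nM, within a range from 15000 nM to 120000 nM.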

Compound 3, half-maximal inhibitory concentration: 39300 nM
Compound 3: the middle estimate sits 1.1-fold (0.06 log units) above what was measured, and the stated range covers the measured number.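

In this assay, the change from 4-chlorophenyl to phenyl gives a 1.4-fold higher number from compound 2 to compound 3 (0.14 log units; within the scatter), so this position now has a measured step, and that step cannot be told from the scatter. The exchange of 3-bromophenyl for 4-bromophenyl on the saturated chain carbon bound to a sulfur can be read only as an at least 1.2-fold lower number from compound 1 to compound 3 (0.10 log units; that floor lies within the scatter), whose floor also lies within the scatter. That step has no upper bound, since the result for compound 1 is a limit and not a number: the limit of > 50000 nM in this assay, at which 1 of the 3 values shown sits.

The compounds shown leave open whether another group in place of the chloro, such as an amine or a carboxylic acid, would shift the number in this assay beyond the scatter. They also leave open how a longer chain between the sulfur and the bromophenyl ring would read.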